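The source may report more compounds than this note shows. Statements on the series, on what has been measured and on what is new or still open speak of the compounds shown alone.

Compound 1 `C/C(=N\NC(=O)c1cccc(S(=O)(=O)N2CCOCC2)c1)c1ccc(F)cc1`: in a functional assay on MCF7 cells (Homo sapiens) for antiproliferative activity, read by MTT assay, with a stated time of 72 h (on this read-out lower numbers stand for stronger inhibition and higher numbers for weaker inhibition), compound 1 reaches only the assay limit > 100000 nM. Compound 2 `C/C(=N\NC(=O)c1cccc(S(=O)(=O)N2CCOCC2)c1)c1ccc(O)cc1`: compound 2 likewise reaches only the assay limit > 100000 nM.

Compound 2 thus stands at the limit, and the step that the two limits leave unreadable from compound 1 to compound 2 cannot be sized because of the limit of > 100000 nM in this assay, at which 2 of the 2 values shown sit. Compound 3 `C/C(=N\NC(=O)c1cccc(S(=O)(=O)N2CCOCC2)c1)c1cccc(N)c1O` differs from compound 2 by 3-amino-2-hydroxyphenyl in place of 4-hydroxyphenyl on a carbon with a double bond to nitrogen. Going by the values given here, the only measured step, a step that the two limits leave unreadable from compound 1 to compound 2, bears on this change yet gives no readable size, so no shift beyond the scatter can be read from it. Compound 3 is therefore expected to give 150000 nM, within 40000 nM to 500000 nM, most probably again as a limit. The expected step that the limit leaves unreadable from compound 2 to compound 3 is essentially none.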

Compound 3, half-maximal inhibitory concentration: 1010 nM
The estimate for compound 3 lay 150-fold (2.17 log units) above the measured number, outside the stated range (below it).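

At the carbon with a double bond to nitrogen, the aryl group can decide whether any activity is read in this assay, which the earlier pair could not show. 3-Amino-2-hydroxyphenyl gives an at least 99-fold lower number from compound 2 to compound 3 (1.99 log units; beyond the scatter) and an at least 99-fold lower number from compound 1 to compound 3 (1.99 log units; beyond the scatter), the first readable value among the compounds shown. Both steps start from a limit of the assay: the limit of > 100000 nM in this assay, at which 2 of the 3 values shown sit.

The compounds shown leave open which part of 3-amino-2-hydroxyphenyl carries the step, as a 3-aminophenyl or a 2-hydroxyphenyl at this place would separate the two. From the compounds shown here alone, how a methoxy in place of its hydroxy would read also stays open.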